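A few compounds are considered here, and "the series" means these few. Any claim that something is new, unique, unknown or untested is made for them only; others in the source may bear on it.

Among the compounds with values here, in a functional assay on KB cells (Homo sapiens) for cytotoxicity (on this read-out lower numbers stand for an effect already at smaller amounts and higher numbers for an effect only at larger amounts of compound), compound 2 (`CC(C)Oc1cc(-c2ccccc2)nc2ccccc12`) gives 4.2 ug/mL, the highest of the three numbers measured so far. Compound 1 (`c1ccc(COc2cc(-c3ccccc3)nc3ccccc23)cc1`) gives 1.6 ug/mL, and compound 3 (`Oc1ccc2c(O)cc(-c3ccccc3)nc2c1`) gives 0.55 ug/mL, the lowest of the three. Compound 4 (`CCCCOc1cc(-c2ccccc2)nc2ccccc12`) has not yet been measured. It differs from compound 2 in one place, with butyl in place of isopropyl on an oxygen on an aromatic ring, a change from isopropoxy to butoxy: butyl in place of isopropyl on an oxygen on an aromatic ring.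

Within the data shown here, no measured pair makes this exact swap. The closest evidence is a 2.6-fold higher number from compound 1 to compound 2 (0.42 log units; beyond the scatter), a modest step that exchanges benzyl for isopropyl on the same oxygen. Among the measured compounds shown here, compound 3 differs from the others in more than one place, so it provides no comparable step. Butyl, like isopropyl, has no ring, so a step smaller than the one between benzyl and isopropyl seems the reasonable expectation, and any movement is expected to lean toward the lower number of compound 1 at 1.6 ug/mL. The expected change is a 1.4-fold lower number from compound 2 to compound 4 (0.15 log units; within the scatter), which would not go beyond the scatter. For compound 4 the estimated value in this assay is 3 ug/mL, with an expected range from 1.4 ug/mL to 6.5 ug/mL.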

Compound 4, half-maximal effective concentration: 3.8 ug/mL
Compound 4: middle estimate off by 1.3-fold (0.10 log units), on the low side, within the range that was stated.
By their numbers in this assay, from the lowest: compound 3; then compound 1; then compounds 4 and 2 (each within the scatter of the next).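

On this oxygen, butyl in place of isopropyl gives a 1.1-fold lower number from compound 2 to compound 4 (0.04 log units; within the scatter) in this assay, so adding one carbon to a ring-free group, in a chain of a different shape, has no effect that this read-out can resolve. Within the data shown here, the earlier compounds gave only a single comparison at this position, benzyl against isopropyl, and could not show whether that gap belonged to isopropyl alone. Now butyl also gives a 2.4-fold higher number from compound 1 to compound 4 (0.38 log units; beyond the scatter), a modest step beyond the scatter, so compound 1, whose benzyl group carries a ring, stands apart from both ring-free compounds, although the data offer no explanation for this gap.

The compounds shown leave open whether the ring itself matters or whether any larger group would do the same, which a phenethyl group or a longer chain such as octyl on this oxygen could help to separate. They also do not say how a group of a different kind, such as an amine or a carboxylic acid at the end of the butyl chain, would change the number in this assay.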